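The source may hold more compounds than are shown below. What is called first, only, known or untested is meant among the compounds shown, and "the series" means these compounds.

Compound 1 `Cc1cc(C)cc(/C=C(/SCc2ccc(F)cc2)C(=O)c2ccc(Br)cc2)c1` and compound 3 `CN(C)c1ccc(/C=C(/SCc2ccc(F)cc2)C(=O)c2ccc(Br)cc2)cc1` share one core and differ in a single group. Compound 2 `Cc1cc(C)cc(/C=C(/Sc2ccc(Br)cc2)C(=O)c2ccc(Cl)cc2)c1` and compound 4 `CN(C)c1ccc(/C=C(/Sc2ccc(Br)cc2)C(=O)c2ccc(Cl)cc2)cc1` share another core and differ in that same single group. How the core of compound 1 differs from the core of compound 2 is not broken down here.

In a functional assay on DU-145 cells (Homo sapiens) for inhibition, read by trypan blue exclusion, with a stated time of 96 h (a lower number here means a stronger inhibitor of growth, a higher number a weaker inhibitor of growth), compound 1 gives 10000 nM. In this assay compound 3 gives 50000 nM. The change from compound 1 to compound 3 is 4-(dimethylamino)phenyl in place of 3,5-dimethylphenyl on a double-bonded chain carbon bound to a double-bonded chain carbon. That change made the step of a 5.0-fold higher number from compound 1 to compound 3 (0.70 log units; beyond the scatter), so the compound carrying the 4-(dimethylamino)phenyl group was the weaker grower inhibitor of the pair.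

In this assay compound 2 gives 10000 nM, which stands level with compound 1 at the digits printed; these two hold the lowest numbers among the three measured compounds, and both sit a clear distance from compound 3.

Compound 4 is not yet measured. Among the measured compounds shown here, its difference from compound 2 is 4-(dimethylamino)phenyl in place of 3,5-dimethylphenyl on a double-bonded chain carbon bound to a double-bonded chain carbon, the same change and the same place as the one that turned compound 1 into compound 3. Because the earlier instance gave a 5.0-fold higher number from compound 1 to compound 3 (0.70 log units; beyond the scatter) and compound 2 starts at 10000 nM, the step from compound 2 to compound 4 is expected to be of similar size, estimated as a 5.0-fold higher number from compound 2 to compound 4 (0.70 log units; beyond the scatter). This rests on a single earlier example, so the expectation is loose. Compound 4 is therefore estimated to give about 50000 nM, with a range expected from 20000 nM to 120000 nM.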

Compound 4, concentration for 50% growth inhibition: > 100000 nM
Compound 4 ended at the assay's limit (the forecaster's own chance of this, stated with the estimate: 25%); middle value at least 2.0-fold (0.30 log units) from the limit.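

In this assay, putting 4-(dimethylamino)phenyl in place of 3,5-dimethylphenyl gave an at least 10-fold higher number from compound 2 to compound 4 (1.00 log units; beyond the scatter), so on both cores the change points the same way, toward weaker inhibition of growth, and on both it lies beyond the scatter. Compound 4 gives > 100000 nM, which is a limit of the assay and not a number: the limit of > 100000 nM in this assay, at which 1 of the 4 values shown sits. On these data alone, the direction of the change therefore carried over from one core to the other, but the size of the step on the second core stays unknown, and it cannot be said whether the change costs more there than on the first: the same change on two cores in this assay, a 5.0-fold higher number (0.70 log units; beyond the scatter) from compound 1 to compound 3 and an at least 10-fold higher number (1.00 log units; beyond the scatter) from compound 2 to compound 4; the limit leaves it open whether they differ.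

The change removes the two methyl groups and brings in the dimethylamino group in a single move, and the compounds shown do not tell which part of that swap goes with the weaker inhibition. As far as these compounds go, it also remains open how other groups on the phenyl in that place, such as a methoxy group or a carboxylic acid, would compare on either core.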